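Swapping the piperazine substituent: aryl to benzyl

The source may hold more compounds than are shown below. What is called first, only, known or untested is meant among the compounds shown, and "the series" means these compounds.

Compound 2 `N#Cc1cccc(COc2ccc(-c3cc(CN4CCN(c5ccc(C(F)(F)F)cn5)CC4)no3)cc2)c1`: 1400 nM
Compound 1 `N#Cc1cccc(COc2ccc(-c3cc(CN4CCN(c5ccc(C(F)(F)F)cc5)CC4)no3)cc2)c1`: 2000 nM

Both compounds share one core and differ only in the group on an amine nitrogen in a ring. In a functional assay on MCF7 cells (Homo sapiens) for antiproliferative activity, read by sulforhodamine B assay, with a stated time of 72 h (on this read-out lower numbers stand for stronger inhibition and higher numbers for weaker inhibition), compound 2 gives 1400 nM, and compound 1 gives 2000 nM. Among the measured compounds shown here, the step of a 1.4-fold lower number from compound 1 to compound 2 (0.15 log units; within the scatter) is the only measured step, and it lies within the scatter, so the two numbers cannot be told apart with confidence. Compound 2 therefore has the lowest of the two numbers, but by a margin that means little.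

Compound 3 `N#Cc1cccc(COc2ccc(-c3cc(CN4CCN(Cc5ccc(F)cc5)CC4)no3)cc2)c1` is not yet measured. The change from compound 2 to compound 3 is 4-fluorobenzyl in place of 5-(trifluoromethyl)pyridin-2-yl on an amine nitrogen in a ring. For the measured compounds named here, no measured step bears directly on this change: the single step known exchanges one aromatic ring for another on the same nitrogen, whereas here an aromatic ring gives way to a benzyl group. Going by the values given here, with no guiding precedent, the expectation is a step of no clear direction beyond the scatter, and the estimate for compound 3 is 2000 nM (range 700 nM to 6000 nM). The expected step is a 1.4-fold higher number from compound 2 to compound 3 (0.15 log units; within the scatter).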

Compound 3, half-maximal inhibitory concentration: 1800 nM
For compound 3 the middle estimate is 1.1-fold (0.05 log units) above the measured one; low and high end bracket the measured number.
By their numbers in this assay, from the lowest: compounds 2, 3 and 1 (each within the scatter of the next).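

On the amine nitrogen in a ring, 4-fluorobenzyl in place of 5-(trifluoromethyl)pyridin-2-yl gives a 1.3-fold higher number from compound 2 to compound 3 (0.11 log units; within the scatter) in this assay, and 4-fluorobenzyl in place of 4-(trifluoromethyl)phenyl gives a 1.1-fold lower number from compound 1 to compound 3 (0.05 log units; within the scatter) in the same read-out. The earlier pair only exchanged one aromatic ring for another on this nitrogen, whereas compound 3 shows that a benzyl group carrying fluorine rather than trifluoromethyl can stand there with a number that cannot be told apart from those of compound 1 and compound 2. Nothing measured on these compounds speaks to what lies behind these numbers.

Going by these compounds, all three groups on this nitrogen carry a six-membered aromatic ring, so it remains open whether the number would hold with a plain methyl, a cyclohexyl group, or a benzyl ring bearing a carboxylic acid. A plain benzyl group and a 4-(trifluoromethyl)benzyl group would also be needed to separate the part played by the ring substituent from that of the benzyl link.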